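A few compounds are considered here, and "the series" means these few. Any claim that something is new, unique, unknown or untested is made for them only; others in the source may bear on it.

Measured so far:
Compound 1 `Clc1ccc(NCc2cncn2Cc2ccc(-c3ccccc3)cc2)cc1-c1ccccc1`: > 1000 nM (a limit)
Compound 2 `Nc1cc(-c2ccccc2)ccc1Cn1cncc1CNc1ccc(Cl)c(-c2ccccc2)c1`: > 1000 nM (a limit)

In a toxicity assay on NIH3T3 cells (Mus musculus) for cytotoxicity, read by resazurin assay (a lower number here means that less compound is needed, a higher number that more compound is needed for the effect), compound 2 gives > 1000 nM. This is a limit of the assay and not a number. Compound 1 gives > 1000 nM, which is also a limit. Going by the values given here, the only measured step is a step that the two limits leave unreadable from compound 1 to compound 2, amino in place of hydrogen on an aromatic carbon, and it has no readable size. All the data show is the limit of > 1000 nM in this assay, at which 2 of the 2 values shown sit.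

Compound 3 `COc1ccc(NCc2cncn2Cc2ccc(-c3ccccc3)cc2N)cc1-c1ccccc1` keeps the amino group of compound 2 but has methoxy in place of chloro on an aromatic carbon, ortho to a phenyl group and para to a large group: methoxy in place of chloro on an aromatic carbon. Among the compounds with values here, no measured step involves this change, so neither its size nor its direction can be drawn from the data. The expectation therefore rests on compound 2 alone, with its limit of > 1000 nM. Nothing beyond the scatter is expected in this assay, and the estimate means a step that the limit leaves unreadable from compound 2 to compound 3. Compound 3 is expected to give 2000 nM, within an estimated range of 800 nM to 10000 nM.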

Compound 3, half-maximal effective concentration: > 1000 nM
Compound 3 gave a limit, no number; the forecaster's own chance of this, stated with the estimate: 85%; the middle value lies beyond the limit too.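

In this assay compound 3 gives > 1000 nM, a limit of the assay and not a number. Compound 2 also stands at a limit, and the step between compound 2 and compound 3 cannot be read. The compounds shown leave open how much of any of them is needed for the effect, and whether the amino or methoxy change alters it: the limit of > 1000 nM in this assay, at which 3 of the 3 values shown sit.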